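The source may hold more compounds than are shown below. What is called first, only, known or untested is meant among the compounds shown, and "the series" means these compounds.

Working notes on the series in a functional assay on HL-60 cells (Homo sapiens) for inhibition, read by MTT assay, with a stated time of 72 h; on this read-out lower numbers stand for stronger inhibition and higher numbers for weaker inhibition. Compound 1 `Cc1nc(-c2ccccc2)c(C(=O)N2CCN(c3ccc(F)cc3)CC2)o1` reads > 1000 nM, which is a limit of the assay and not a number. Among the measured compounds shown here, compound 2 `Cc1nc(-c2ccccc2)c(C(=O)N2CCN(c3cc(Cl)cc(Cl)c3)CC2)o1` reads 41.8 nM, the only actual number so far. For the measured compounds named here, the single measured step, an at least 23-fold lower number from compound 1 to compound 2 (1.37 log units; beyond the scatter), shows that the group on this ring nitrogen can move the read-out by a large amount.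

Next is compound 3 `Cc1nc(-c2ccccc2)c(C(=O)N2CCN(c3cccc(C(F)(F)F)c3)CC2)o1`, with 3-(trifluoromethyl)phenyl in place of 3,5-dichlorophenyl on the same amine nitrogen: 3-(trifluoromethyl)phenyl in place of 3,5-dichlorophenyl on an amine nitrogen in a ring. Going by the values given here, both groups are a six-membered aromatic ring of carbon only, so the change is smaller than the swap behind an at least 23-fold lower number from compound 1 to compound 2 (1.37 log units; beyond the scatter), yet only that one step bears on it. A moderately higher number is expected, with an estimated 2.9-fold higher number from compound 2 to compound 3 (0.46 log units; beyond the scatter) in this assay. For compound 3 the expected value is 120 nM, with an estimated range of 35 nM to 450 nM.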

Compound 3, half-maximal inhibitory concentration: 153 nM
For compound 3 the middle estimate is 1.3-fold (0.11 log units) below the measured one; measured number inside the range.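

In this assay, two groups on the amine nitrogen now give actual numbers, and they are not interchangeable: a 3.7-fold higher number from compound 2 to compound 3 (0.56 log units; beyond the scatter). The large drop seen on leaving 4-fluorophenyl is therefore not confined to 3,5-dichlorophenyl, as 3-(trifluoromethyl)phenyl also gives a lower number, with an at least 6.5-fold lower number from compound 1 to compound 3 (0.81 log units; beyond the scatter). The reading for compound 1 is a limit and not a number, so that step gives only a minimum size: the limit of > 1000 nM in this assay, at which 1 of the 3 values shown sits.

Still open, as far as these compounds go, is how a single chlorine, a methoxy group or a nitrile on the phenyl ring would read, or a cyclohexyl group on the same amine nitrogen. Also open, from the compounds shown here alone, is how a change elsewhere on the shared core would read.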